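Removing One Ring Fluorine From an Oral Exposure Lead

This account rests on a few compounds, and the source may have more. Where it says the series, first, only, none or still open, it means among the compounds named here.

Two compounds were followed in an ADME assay on the whole organism for pharmacokinetics, with Rattus norvegicus as the target, with a stated time of 6 h, at a dose of 10 mg/kg by the oral route; on this read-out higher numbers stand for higher exposure at the dose given and lower numbers for lower exposure. Compound 1 `CC(C)S(=O)(=O)N1CCN(c2cnn(-c3cccc(F)c3)c(=O)c2OC2CCC(F)C2)CC1` gives 300 ng.h/mL. Compound 2 `CC(C)S(=O)(=O)N1CCN(c2cnn(-c3cc(F)cc(F)c3)c(=O)c2OC2CCC(F)(F)C2)CC1` gives 440 ng.h/mL, a number within the scatter of compound 1, so the two cannot be told apart. Compound 3 `CC(C)S(=O)(=O)N1CCN(c2cnn(-c3cc(F)cc(F)c3)c(=O)c2OC2CCC(F)C2)CC1` is not yet measured. It differs from compound 2 by hydrogen in place of fluoro on a saturated ring carbon. Within the data shown here, no measured pair shows this change alone, so the step is expected to be small, likely toward somewhat lower exposure, and estimated as a 1.3-fold lower number from compound 2 to compound 3 (0.12 log units; within the scatter). For compound 3 the expected value in this assay is 330 ng.h/mL, with a range from 140 ng.h/mL to 800 ng.h/mL.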

Compound 3, area under the concentration-time curve: 2100 ng.h/mL
Compound 3: middle estimate off by 6.4-fold (0.80 log units), on the low side; measured number above the stated range.
By their numbers in this assay, from the lowest: compounds 1 and 2 (each within the scatter of the next); then compound 3.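

In this assay the change from 3,3-difluorocyclopentyl to 3-fluorocyclopentyl gives a 4.8-fold higher number from compound 2 to compound 3 (0.68 log units; beyond the scatter) and so a single fluoro on this saturated ring carbon clearly affects exposure. With the 3-fluorocyclopentyl kept, fluoro in place of hydrogen on an aromatic carbon gives a 7.0-fold higher number from compound 1 to compound 3 (0.85 log units; beyond the scatter) and so the aromatic ring matters as well. Nothing shown explains why either change raises exposure. Open still is how a plain cyclopentyl, with no fluoro at all, would behave, or one carrying a hydroxyl or an amine on this ring carbon.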